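The compounds below may be only part of what the source reports. "The series", "measured", "known", "first", "only" and "open" are said of these compounds alone.

Measured compounds:
compound 1 `CCOCC1CN(c2ccccc2)NC1=O` — 1.42
compound 2 `CCCOCC1CN(c2ccccc2)NC1=O` — 1.95
compound 3 `CSC1CN(c2ccccc2)NC1=O` — 1.97

In a physicochemical assay for lipophilicity (a lower number here means a more polar compound, a higher number a more lipophilic compound), compound 1 gives 1.42, compound 2 gives 1.95 and compound 3 gives 1.97. Compound 4 `CCSC1CN(c2ccccc2)NC1=O` is not yet measured in this assay.

The change from compound 1 to compound 2 is methyl in place of hydrogen on a saturated chain carbon, two bonds along the chain from an oxygen on a saturated carbon; it made a number 0.53 log units higher from compound 1 to compound 2 (beyond the scatter). The change from compound 3 to compound 4 is methyl in place of hydrogen on a saturated chain carbon bound to a sulfur. The two are the same kind of change, a methyl entering for a hydrogen on a saturated chain carbon, but not the same: in compound 2 the place is two bonds along the chain from an oxygen on a saturated carbon, in compound 4 the place is a carbon bound to a sulfur. The cores also differ: compound 3 differs from compound 1 by methylsulfanyl in place of ethoxymethyl on a saturated ring carbon.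

Compound 3 and compound 2 show values within the scatter of each other. Among the measured compounds shown here, a step of about the same size as the one from compound 1 to compound 2 is expected from compound 3 to compound 4 in this assay, a number 0.50 log units higher from compound 3 to compound 4 (beyond the scatter), resting on a number 0.53 log units higher from compound 1 to compound 2 (beyond the scatter) as the only measured example of this kind of change. For compound 4 the estimate is 2.47, between 2.15 and 2.8.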

Compound 4, partition coefficient: 2.5
Compound 4: middle estimate off by 0.03 log units, on the low side, and the stated range covers the measured number.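

In this assay the entry of a methyl for a hydrogen gives a number 0.53 log units higher from compound 3 to compound 4 (beyond the scatter) and, on the core of compound 1, a number 0.53 log units higher from compound 1 to compound 2 (beyond the scatter) as a step of the same printed size, so the change carries over between a saturated chain carbon bound to a sulfur and one two bonds along the chain from an oxygen on a saturated carbon. The exchanges of whole groups give a number 0.55 log units higher from compound 2 to compound 4 (beyond the scatter) for ethylsulfanyl in place of propoxymethyl and a number 1.08 log units higher from compound 1 to compound 4 (beyond the scatter) for ethylsulfanyl in place of ethoxymethyl, and these do not isolate the methyl change. One pair of steps shows agreement for these compounds only and sets no rule for the series, and nothing measured here accounts for that agreement.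

Still open, on these data alone, is whether the step holds for a longer chain on the sulfur, such as propylsulfanyl, or on a further core. Also open, as far as these compounds go, is what this assay would read for an amine or a carboxylic acid in place of ethylsulfanyl.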